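Biaryl-pyridine amides and urea: inhibition at one concentration

This account rests on a few compounds, and the source may have more. Where it says the series, first, only, none or still open, it means among the compounds named here.

Measured so far:
compound 1 `O=C(Nc1ccccc1)Nc1ccc(-c2ccccc2)cn1` — 20%
compound 2 `O=C(Nc1ccc(-c2ccccc2)cn1)c1ccc(Cl)cc1` — 0%
compound 3 `O=C(Nc1ccc(-c2ccccc2)cn1)c1ccc(Cl)c(Cl)c1` — 13%

In an assay on isolated protein (Aquatica lateralis) for inhibition of Luciferin 4-monooxygenase (Luciola lateralis), read by a luciferase reporter, tested at 10 uM (a higher number here means more inhibition at the concentration tested (going by the name of the read-out), a lower number less inhibition), compound 2 stands lowest of the three numbers; compound 3 lies a number 13 percentage points higher from compound 2 to compound 3 (beyond the scatter) and the other measured step is a number 20 percentage points lower from compound 1 to compound 2 (beyond the scatter). The unmeasured compound 4 `CN(C)c1ccc(C(=O)Nc2ccc(-c3ccccc3)cn2)cc1` follows from compound 2 by one change: dimethylamino in place of chloro on an aromatic carbon. The group sits on an aromatic carbon of a six-membered aromatic ring of carbon only, para to a large group.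

For the measured compounds named here, two measured steps bear on this. The step from compound 2 to compound 3 puts a second chloro on the same ring and gives a number 13 percentage points higher from compound 2 to compound 3 (beyond the scatter), a modest rise. The step from compound 1 to compound 2 swaps the anilino for 4-chlorophenyl on the carbonyl carbon and gives a number 20 percentage points lower from compound 1 to compound 2 (beyond the scatter), a modest fall. Going by the values given here, neither step exchanges the chloro itself for another group, so no direct precedent exists for dimethylamino here. Changes to this ring have so far moved this assay by modest amounts only, so the expectation is a small step, probably not beyond the scatter, with a slight lean upward because compound 3 already shows 13% after an addition on the same ring.

Compound 4 is therefore expected to give 6% in this assay, in the range -8% to 24%. The expected step is a number 6 percentage points higher from compound 2 to compound 4 (within the scatter).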

Compound 4, a percentage reported as inhibition, at one concentration (the size of the read-out at that concentration, not a potency): 35%
Compound 4: the middle estimate sits 29 percentage points below what was measured; measured number outside the range, above it.
By their numbers in this assay, from the lowest: compound 2; then compounds 3 and 1 (each within the scatter of the next); then compound 4.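

Working notes: in this assay the exchange of chloro for dimethylamino on an aromatic carbon, para to a large group, gives a number 35 percentage points higher from compound 2 to compound 4 (beyond the scatter) and is the first large step in this short series. The earlier change on this ring, a number 13 percentage points higher from compound 2 to compound 3 (beyond the scatter), kept the existing chloro and added a second one, so it did not show what replacing that chloro would do; this position now proves able to carry a much bigger change in the read-out than that addition suggested. No measurement shown here accounts for the size of this step, and the result stands as one observed exchange at one concentration.

Still open, going by these compounds, is whether the rise is particular to dimethylamino or also appears with a primary amine, a methoxy group or a pyrrolidine at the same place, and whether a carboxylic acid there moves the number the same way. Also open, on these data alone, is whether dimethylamino on the anilino group of compound 1 would give a step of similar size.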